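The compounds below may be only part of what the source reports. "The series", "measured", "known", "first", "only" and "open" are said of these compounds alone.

Measured so far in an ADME assay on THP-1 cells (Homo sapiens) for cytotoxicity, read by MTT assay, with a stated time of 72 h; a lower number here means that less compound is needed, a higher number that more compound is needed for the effect:
Compound 1 `Cc1ccc(-c2ccc3[nH]c(=O)nc(-c4ccccc4)c3c2)cn1` sits at a limit of the assay, > 50000 nM.
Compound 2 `O=c1nc(-c2ccccc2)c2cc(-c3ccc(N4CCCC4)nc3)ccc2[nH]1` sits at a limit of the assay, > 50000 nM.
Compound 3 `O=c1nc(-c2ccccc2)c2cc(-c3cnc4ccccc4c3)ccc2[nH]1` sits at a limit of the assay, > 50000 nM.

Compound 1 therefore stands only as a limit in this assay, with no number. All three values shown sit at the limit of > 50000 nM in this assay, at which 3 of the 3 values shown sit. For the measured compounds named here, the one recorded step, a step that the two limits leave unreadable from compound 1 to compound 2, is consequently not readable.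

Compound 4 `O=c1nc(-c2ccccc2)c2cc(-c3cccc(F)c3)ccc2[nH]1` differs from compound 1 by 3-fluorophenyl in place of 6-methylpyridin-3-yl on an aromatic carbon. Going by the values given here, no measured step bears on this change, so nothing beyond the scatter is expected in this assay. Compound 4 is expected to remain at the limit, with an estimate of 80000 nM (range 30000 nM to 300000 nM). The step this estimate means, a step that the limit leaves unreadable from compound 1 to compound 4, is expected to be unreadable.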

Compound 4, half-maximal effective concentration: > 50000 nM
Compound 4 ended at the assay's limit; the forecaster's own chance of this, stated with the estimate: 85%; the middle value lies beyond the limit too.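

The step from compound 1 to compound 4 cannot be read, as both compounds stand only at a limit in this assay: the limit of > 50000 nM in this assay, at which 4 of the 4 values shown sit.

The compounds shown leave open whether any group at this place on the shared core gives a readable number in this assay.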